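Oxygen to Sulfur Swap on a Diamino Quinoxaline Core

This account rests on a few compounds, and the source may have more. Where it says the series, first, only, none or still open, it means among the compounds named here.

Compound 1 `Nc1cc(N)c2nc(-c3ccccc3)c(Oc3ccc(Cl)c(Cl)c3)nc2c1` — 12000 nM
Compound 2 `COc1ccc(CNc2nc3cc(N)cc(N)c3nc2-c2ccccc2)cc1OC` — 17000 nM
Compound 3 `CCOC(=O)[C@H](CCC(=O)O)NC(=O)c1ccc(Oc2nc3cc(N)cc(N)c3nc2-c2ccccc2)cc1` — < 100000 nM

In a functional assay on U-251 cells (Homo sapiens) for inhibition, read by sulforhodamine B assay, with a stated time of 48 h (on this read-out lower numbers stand for stronger inhibition of growth and higher numbers for weaker inhibition of growth), compound 1 gives 12000 nM. Compound 2 gives 17000 nM in this assay, and the two values lie within the usual scatter of each other, so neither can be set apart from the other. For compound 3 this assay reports only a limit, < 100000 nM, and not a number; the limit of < 100000 nM in this assay, at which 1 of the 3 values shown sits, applies to one of the three values shown. Compound 1 thus stands among the lowest numbers shown, but without a measured companion that differs from it in a single place.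

Compound 4 `Nc1cc(N)c2nc(-c3ccccc3)c(Sc3ccc(Cl)c(Cl)c3)nc2c1` is such a companion: it carries (3,4-dichlorophenyl)sulfanyl in place of 3,4-dichlorophenoxy on an aromatic carbon. Among the compounds with values here, no measured step of this kind is available, so the size of the change from compound 1 to compound 4 in this assay can only be guessed. The account expects the step from compound 1 to compound 4 to be small, a 1.2-fold lower number from compound 1 to compound 4 (0.08 log units; within the scatter), with no direction claimed beyond the scatter. Compound 4 is therefore estimated at 10000 nM, with a range from 3500 nM to 30000 nM.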

Compound 4, concentration for 50% growth inhibition: 10200 nM
For compound 4 the middle estimate is 1.0-fold (0.01 log units) below the measured one; low and high end bracket the measured number.
By their numbers in this assay, from the lowest: compounds 4, 1 and 2 (each within the scatter of the next).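

In this assay, within the data shown here, the (3,4-dichlorophenyl)sulfanyl group in place of 3,4-dichlorophenoxy gives a 1.2-fold lower number from compound 1 to compound 4 (0.07 log units; within the scatter) and so offers the first comparison in this set between compounds that differ in one place. On this aromatic carbon next to the ring nitrogen, the oxygen and sulfur forms cannot be told apart on this read-out, so the exchange of these two atoms leaves growth inhibition unchanged within the scatter. Nothing measured here bears on why the step is this size.

The compounds shown leave open how a sulfone or a methylene link at the same place would read in this test. They also leave open whether the two chlorine atoms matter, since an unsubstituted phenyl ring or a phenyl ring carrying a carboxylic acid does not appear among them.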